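The source may report more compounds than this note shows. Statements on the series, on what has been measured and on what is new or still open speak of the compounds shown alone.

Compound 3 `CNc1cc(Cl)c(C(=O)Nc2ccc(O)c(C(C)(C)C)c2)c(Cl)c1` is tested in an assay on isolated protein for antagonist activity at Bile acid receptor (Homo sapiens), read by HTRF, with a stated time of 30 min (a higher number here means a weaker inhibitor, a lower number a stronger inhibitor), where compound 3 gives 13900 nM. Of the three compounds measured, compound 3 shows the largest number. Its gap to compound 2 `CC(C)(C)c1cc(NC(=O)c2c(Cl)cc(NCc3ccncc3)cc2Cl)ccc1O`, which in this assay gives 9800 nM, is a 1.4-fold higher number from compound 2 to compound 3 (0.15 log units; within the scatter), so these two cannot be told apart. Its gap to compound 1 `CC(C)(C)c1cc(NC(=O)c2c(Cl)cc(N)cc2Cl)ccc1O`, which gives 5200 nM, is a 2.7-fold higher number from compound 1 to compound 3 (0.43 log units; beyond the scatter), a modest but real difference.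

Compound 4 `CC(C)(C)c1cc(NC(=O)c2c(Cl)cc(N3CCNCC3)cc2Cl)ccc1O` has not yet been measured. It differs from compound 3 by piperazin-1-yl in place of methylamino on an aromatic carbon. Going by the values given here, the steps that bear on this are the changes made at the same nitrogen: a 2.7-fold higher number from compound 1 to compound 3 (0.43 log units; beyond the scatter) and a 1.9-fold higher number from compound 1 to compound 2 (0.28 log units; within the scatter), the second within the scatter. Among the compounds with values here, no measured pair compares a ring joined directly to the aromatic carbon at this position, so the expectation is an indirect one. Since every alteration at this nitrogen so far moved the number little, the step of a 1.4-fold lower number from compound 3 to compound 4 (0.14 log units; within the scatter) is expected to stay near the scatter, with no clear direction. Compound 4 is therefore estimated at 10000 nM, with a range of 3000 nM to 35000 nM.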

Compound 4, half-maximal inhibitory concentration: > 100000 nM
Compound 4 gave a limit, no number (the forecaster's own chance of this, stated with the estimate: 15%); middle value at least 10-fold (1.00 log units) away from the limit.
By their numbers in this assay, from the lowest: compounds 1, 2 and 3 (each within the scatter of the next, the first and the last beyond it). At a limit, above all of these: compound 4.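

Compound 4 gives a limit, not a number: the limit of > 100000 nM in this assay, at which 1 of the 4 values shown sits. Until now, changes at this nitrogen moved the number modestly at most, but the piperazin-1-yl group breaks that picture, with an at least 7.1-fold higher number from compound 3 to compound 4 (0.85 log units; beyond the scatter), an at least 10-fold higher number from compound 2 to compound 4 (1.00 log units; beyond the scatter) and an at least 19-fold higher number from compound 1 to compound 4 (1.28 log units; beyond the scatter). This position therefore tolerates amino, methylamino and ((pyridin-4-yl)methyl)amino, but not a six-membered non-aromatic ring with 2 hetero atoms joined directly to the aromatic carbon.

From the compounds shown here alone, what remains open is which feature of the piperazin-1-yl group matters: the ring itself, its second nitrogen, or the loss of the hydrogen on the nitrogen attached to the aromatic carbon. Morpholin-4-yl, piperidin-1-yl and an open-chain dimethylamino group at this carbon would help to separate these possibilities.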